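The source may hold more compounds than are shown below. What is called first, only, known or untested is meant among the compounds shown, and "the series" means these compounds.

Measured compounds:
compound 1 `CN1CCc2nc(C#Cc3cccnc3)ccc2C1=O`, in a functional assay on HEK293 cells for positive allosteric modulation of metabotropic glutamate receptor 5 (Homo sapiens), read by FLIPR and calcium flux (a lower number here means that less compound is needed, a higher number that more compound is needed for the effect), reported as "not active" (no number reported)
compound 2 `O=C1c2ccc(C#Cc3ccc(Cl)cc3)nc2CCN1C1CCCC1`, compound 2 gives 979 nM
compound 3 `Cc1ccccc1C#Cc1ccc2c(n1)CCN(C1CCCCC1)C2=O`, compound 3 gives 466 nM

Of the two compounds with a number, compound 3 has the lower one, and its distance from compound 2 lies beyond the usual scatter; compound 1 contributes no number. The next compound, compound 4 `O=C1c2ccc(C#Cc3cccc(Cl)c3)nc2CCN1C1CCCCC1`, keeps the whole of compound 3 apart from the group at the end of the triple bond: 3-chlorophenyl in place of 2-methylphenyl on a triple-bonded carbon. For the measured compounds named here, no step between two measured compounds shows this change, so its size is not known from these data. Because compound 3 already gives 466 nM and the change swaps one small group for another of the same size and ring type, the expected step from compound 3 to compound 4 is a 1.3-fold lower number from compound 3 to compound 4 (0.12 log units; within the scatter), a step not clearly beyond the scatter in either direction. The estimate for compound 4 in this assay is therefore 350 nM, with a likely range from 120 nM to 1200 nM.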

Compound 4, half-maximal effective concentration: 171 nM
Beside the measured number, compound 4's estimate is 2.0-fold (0.31 log units) above it; low and high end bracket the measured number.
By their numbers in this assay, from the lowest: compound 4; then compound 3; then compound 2.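

In this assay, the step that replaces 2-methylphenyl with 3-chlorophenyl is a 2.7-fold lower number from compound 3 to compound 4 (0.44 log units; beyond the scatter). This is the first pair shown that differs in one place only, so it shows that the group on the triple-bonded carbon can, by itself, move the number beyond the scatter. That shift occurs even though the two groups have the same count of heavy atoms and the same type of ring, and no data shown here explain the difference.

The step changes both the substituent, methyl to chlorine, and its ring position, so the contribution of each remains unresolved. The compounds shown leave open how 2-chlorophenyl or 3-methylphenyl would compare on the same core, and whether a 3-methoxyphenyl or 3-cyanophenyl group would lower the number further.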